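From Butyl Chain to 4-Fluorophenyl: an Expected Dose

This account rests on a few compounds, and the source may have more. Where it says the series, first, only, none or still open, it means among the compounds named here.

Compound 1 `CCCCCCN1CCC(C(=O)Nc2cc(Cl)c(N)cc2OC)CC1` gives > 10 mg/kg in a functional assay on the whole organism for antagonist activity, with Mus musculus as the target (on this read-out lower numbers stand for an effect already at smaller amounts and higher numbers for an effect only at larger amounts of compound), which is a limit of the assay rather than a number.
Compound 2 `COc1cc(N)c(Cl)cc1NC(=O)C1CCN(CC2CCC2)CC1` gives > 10 mg/kg in this assay, again a limit.
Compound 3 `CCCCCN1CCC(C(=O)Nc2cc(Cl)c(N)cc2OC)CC1` gives > 10 mg/kg in this assay, again a limit.

Compound 3 thus stands at the limit of the assay, as do the other two values shown: the limit of > 10 mg/kg in this assay, at which 3 of the 3 values shown sit. None of the three measured compounds reached a half-maximal effect within the tested range, so no number is known for any of them. The steps among them are a step that the two limits leave unreadable from compound 1 to compound 2, a step that the two limits leave unreadable from compound 1 to compound 3 and a step that the two limits leave unreadable from compound 2 to compound 3, each of unreadable size; both ends of each sit at the limit.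

Compound 4 `COc1cc(N)c(Cl)cc1NC(=O)C1CCN(Cc2ccc(F)cc2)CC1` differs from compound 3 in one place: 4-fluorophenyl in place of butyl on a saturated chain carbon bound to an amine nitrogen in a ring. Going by the values given here, no measured step turns the chain on the ring nitrogen into an aromatic group, and the steps that do alter this chain cannot be read. There is no basis for expecting a step of any particular direction or size. Because compound 3 gives > 10 mg/kg, a limit, compound 4 is expected most likely to be reported as a limit as well. The estimate for compound 4 is 15 mg/kg, ranging from 2 mg/kg to 60 mg/kg. This estimate corresponds to an expected step that the limit leaves unreadable from compound 3 to compound 4.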

Compound 4, dose for half-maximal effect: 0.6 mg/kg
Compound 4: middle estimate off by 25-fold (1.40 log units), on the high side; the whole stated range lies above it.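

The group on the saturated chain carbon bound to the ring's amine nitrogen turns out to matter strongly in this assay: putting 4-fluorophenyl there gives an at least 16-fold lower number from compound 3 to compound 4 (1.22 log units; beyond the scatter). The same change measured against the other two chains gives an at least 16-fold lower number from compound 2 to compound 4 (1.22 log units; beyond the scatter) and an at least 16-fold lower number from compound 1 to compound 4 (1.22 log units; beyond the scatter), so butyl, cyclobutyl and pentyl all stand apart from 4-fluorophenyl on the shared core. The steps among the first three compounds cannot be read, and the sizes of the new steps are bounded rather than exact, since only compound 4 has a number and the other compounds give only a limit: the limit of > 10 mg/kg in this assay, at which 3 of the 4 values shown sit.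

Compound 4 brings in an aromatic ring and a fluorine together, so the compounds shown leave open which of the two carries the change, a question that plain phenyl in the same place would help to settle. They also leave open whether the ring must be carbon only, as a pyridine ring would test, and how far each of the three chains really lies beyond its limit.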